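Swapping bromo for methyl in compound 3

A few compounds are considered here, and "the series" means these few. Any claim that something is new, unique, unknown or untested is made for them only; others in the source may bear on it.

Compound 3 `O=S(=O)(NCCCNc1nccc(-c2[nH]c(-c3ccccc3)nc2-c2ccc(Cl)c(O)c2)n1)c1ccc(Br)cc1` is the starting point. In a functional assay on LOX IMVI cells (Homo sapiens) for cytotoxicity, read by MTT assay, with a stated time of 24 h (on this read-out higher numbers stand for weaker inhibition and lower numbers for stronger inhibition), compound 3 gives 15500 nM. Two relatives frame that number. Compound 1 `COc1cc(-c2nc(-c3ccccc3)[nH]c2-c2ccnc(NCCCNS(=O)(=O)c3ccc(C)cc3)n2)ccc1F` gives 2590 nM, which is on the stronger side of compound 3 and beyond the usual scatter. Compound 2 `Cc1ccc(S(=O)(=O)NCCCNc2nccc(-c3[nH]c(-c4ccccc4)nc3-c3ccc(F)c(O)c3)n2)cc1` gives 26300 nM, which is within the scatter of compound 3, so these two cannot be told apart.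

The next compound, compound 4 `Cc1ccc(S(=O)(=O)NCCCNc2nccc(-c3[nH]c(-c4ccccc4)nc3-c3ccc(Cl)c(O)c3)n2)cc1`, has methyl in place of bromo on an aromatic carbon, para to a large group (methyl in place of bromo on an aromatic carbon).

For the measured compounds named here, only one measured step exists, a 10-fold higher number from compound 1 to compound 2 (1.01 log units; beyond the scatter). That step is large, but it lies elsewhere in the molecule, where hydrogen replaces methyl on an oxygen on an aromatic ring, so it says little directly about this swap. A nearer hint is that compound 2 also carries the 4-methylphenyl group, and compound 3 lies within the scatter of compound 2 at 26300 nM. No step beyond the scatter is therefore expected in this assay, and the estimated change is a 1.2-fold higher number from compound 3 to compound 4 (0.06 log units; within the scatter). For compound 4 the expected value is 18000 nM, with an estimated range from 7000 nM to 42000 nM.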

Compound 4, half-maximal inhibitory concentration: 6020 nM
Compound 4: the middle estimate sits 3.0-fold (0.48 log units) above what was measured; measured number below the stated range.
By their numbers in this assay, from the lowest: compound 1; then compound 4; then compounds 3 and 2 (each within the scatter of the next).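

The swap of bromo for methyl gives a 2.6-fold lower number from compound 3 to compound 4 (0.41 log units; beyond the scatter) in this assay and so shows that this position on the sulfonyl-bearing ring affects the read-out, even though only one heavy atom is exchanged for another. With the 4-methylphenyl group held constant, the other ring also responds to a single change, as chloro in place of fluoro gives a 4.4-fold lower number from compound 2 to compound 4 (0.64 log units; beyond the scatter) and places compound 4 clearly apart from both halogen-bearing relatives that share its hydroxyl group. Even so, the 4-chloro-3-hydroxyphenyl group of compound 4 does not match the 4-fluoro-3-methoxyphenyl group of compound 1, since that exchange gives a 2.3-fold higher number from compound 1 to compound 4 (0.37 log units; beyond the scatter) and leaves compound 1 with the lowest number of the four.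

The compounds shown leave open whether an amine, a methoxy group or a carboxylic acid at this position on the sulfonyl-bearing ring would lower the number further, and whether methyl would still beat bromo with a methoxy group on the other ring. Nothing presented here explains why methyl gives a lower number than bromo at this position.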